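The source may hold more compounds than are shown below. What is called first, only, known or untested is meant among the compounds shown, and "the series" means these compounds.

Compound 1 `COc1ccc(C(=O)/C=C/c2ccc(OCc3cn(Cc4ccccc4)nn3)cc2)cc1` gives the lowest of the two numbers measured in a functional assay on MIA PaCa-2 cells (Homo sapiens) for cytotoxicity, read by MTT assay, with a stated time of 48 h (on this read-out lower numbers stand for stronger inhibition and higher numbers for weaker inhibition), namely 4000 nM. Going by the values given here, compound 2 `COc1ccc(C(=O)/C=C/c2ccc(OCc3cn(Cc4ccccc4Br)nn3)cc2)cc1` gives 10000 nM in this assay, and the only step known is a 2.5-fold higher number from compound 1 to compound 2 (0.40 log units; beyond the scatter). Compound 3 `COc1ccc(C(=O)/C=C/c2ccc(OCc3cn(Cc4cccc(Br)c4)nn3)cc2)cc1` differs from compound 1 by bromo in place of hydrogen on an aromatic carbon. Among the compounds with values here, the step from compound 1 to compound 2 put the same bromo on the same ring, only at another place, and it is the sole guide here. A modest weakening is therefore expected, a 1.5-fold higher number from compound 1 to compound 3 (0.18 log units; within the scatter). Compound 3 is estimated at 6000 nM, with a range of 2500 nM to 15000 nM.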

Compound 3, half-maximal inhibitory concentration: 10000 nM
For compound 3 the middle estimate is 1.7-fold (0.22 log units) below the measured one, and the stated range covers the measured number.
By their numbers in this assay, from the lowest: compound 1; then compounds 2 and 3 (each within the scatter of the next).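

The bromo costs about the same at this new place on the benzyl ring, with a 2.5-fold higher number from compound 1 to compound 3 (0.40 log units; beyond the scatter) and no change at the digits printed from compound 2 to compound 3 (within the scatter). So in this assay the two bromo placements cannot be told apart, and both compound 2 and compound 3 stand weaker than compound 1, which has no bromo. Nothing here gives the reason for this loss. Going by these compounds, it remains open whether a different group at this place, such as an amine, a carboxylic acid or a methoxy, would follow the bromo or restore strength.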